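The source may report more compounds than this note shows. Statements on the series, on what has been measured and on what is new or still open speak of the compounds shown alone.

The measured compounds are compound 1 `CN(C)c1nc2c(ncn2-c2ccccc2)c(=O)n1-c1ccccc1`, compound 2 `CC(C)N(c1nc2c(ncn2-c2ccccc2)c(=O)n1-c1ccccc1)C(C)C` and compound 3 `O=c1c2ncn(-c3ccccc3)c2nc(N2CCCCC2)n1-c1ccc(Cl)cc1`. In a functional assay on HepG2 cells (Homo sapiens) for cytotoxicity, read by MTT assay, with a stated time of 72 h (on this read-out higher numbers stand for weaker inhibition and lower numbers for stronger inhibition), compound 1 gives > 100000 nM, which is a limit of the assay. In this assay compound 2 gives > 100000 nM, also a limit. In this assay compound 3 gives > 100000 nM, again a limit. Compound 2 therefore stands at the limit of > 100000 nM in this assay, at which 3 of the 3 values shown sit, with no number of its own. The change to compound 4 `CCNc1nc2c(ncn2-c2ccccc2)c(=O)n1-c1ccccc1` is ethylamino in place of diisopropylamino on an aromatic carbon. Among the measured compounds shown here, the only measured step at this position is a step that the two limits leave unreadable from compound 1 to compound 2, whose size the limits do not reveal. No step beyond the scatter is expected in this assay. Compound 4 is expected to give 150000 nM, with a range from 50000 nM to 500000 nM. That estimate for compound 4 means a step that the limit leaves unreadable from compound 2 to compound 4, expected to stay within the scatter.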

Compound 4, half-maximal inhibitory concentration: > 100000 nM
Compound 4: no number, only a limit; the forecaster's own chance of this, stated with the estimate: 85%; the middle value lies beyond the limit too.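

In this assay the steps to compound 4 from compound 1 and from compound 2 cannot be read, since these compounds give only a limit: the limit of > 100000 nM in this assay, at which 4 of the 4 values shown sit. The compounds shown leave open which change to the shared core, if any, would give a measurable value.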